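From Fluoromethyl to Hydroxymethyl: an Expected Cytotoxicity Value

The source may hold more compounds than are shown below. What is called first, only, known or untested is meant among the compounds shown, and "the series" means these compounds.

Compounds measured in a functional assay on HeLa cells (Homo sapiens) for cytotoxicity, read by WST assay, with a stated time of 48 h; a higher number here means a weaker inhibitor, a lower number a stronger inhibitor:
compound 1, `COc1cc(C(c2ccc(O)c(OC)c2)[C@H](C)[C@@H](C)CF)ccc1O`, gives 34000 nM
compound 2, `COc1ccc(C(c2ccc(OC)c(OC)c2)[C@H](C)[C@H](C)CO)cc1OC`, gives > 100000 nM

Within the data shown here, compound 1 holds the only numerical value shown in this assay. The value of compound 2 is a limit of the assay and not a number, and it sits at the limit of > 100000 nM in this assay, at which 1 of the 2 values shown sits. Among the measured compounds shown here, no two measured compounds differ in a single place, so no step between them can be read; the two values show only that compound 1 gives a number where compound 2 gives a limit.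

Compound 3, `COc1cc(C(c2ccc(O)c(OC)c2)[C@@H](CO)C(C)C)ccc1O`, is not yet measured. It differs from compound 1 by 1-(hydroxymethyl)-2-methylpropyl in place of 2-(fluoromethyl)-1-methylpropyl on a saturated chain carbon bound to two aromatic carbons.

For the measured compounds named here, with no measured step to lean on, the account can only state an expectation. The step from compound 1 to compound 3 in this assay is expected to be small and towards weaker inhibition, about a 1.8-fold higher number from compound 1 to compound 3 (0.25 log units; within the scatter). Compound 3 is therefore estimated to give 60000 nM, with a range from 20000 nM to 150000 nM, and a real chance that this assay reports only a limit.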

Compound 3, half-maximal inhibitory concentration: > 100000 nM
Compound 3: only a limit was reported (the forecaster's own chance of this, stated with the estimate: 35%); middle value at least 1.6-fold (0.22 log units) from the limit.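

In this assay, the change at this position, on a saturated chain carbon bound to two aromatic carbons, now gives a step that can be read: an at least 2.9-fold higher number from compound 1 to compound 3 (0.46 log units; beyond the scatter). The position is therefore not indifferent to this exchange, even though 6 heavy atoms leave and 6 enter, with no ring and no net charge on either side. The change has several parts, since a fluorine gives way to an oxygen, a hydrogen-bond donor and acceptor enter where none leave, and the chain itself is arranged differently, while the value of compound 3 is a limit of the assay and not a number, a place it shares with one other compound: the limit of > 100000 nM in this assay, at which 2 of the 3 values shown sit.

From the compounds shown here alone, the true size of the step stays open, and so does the question of which part of the exchange carries it, the loss of the fluoromethyl group, the arrival of the hydroxymethyl group or the new branching. Also open, going by these compounds, is how an aminomethyl group or a longer chain in the same place would read in this assay.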